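This account rests on a few compounds, and the source may have more. Where it says the series, first, only, none or still open, it means among the compounds named here.

Compound 1 `Cc1ccc(NS(=O)(=O)c2ccc(C(C)(C)C)cc2)cc1O` and compound 2 `Cc1ccc(NS(=O)(=O)c2ccc(-c3ccccc3)cc2)cc1O` share one core and differ in a single place: phenyl in place of tert-butyl on an aromatic carbon. In a functional assay on A549 cells (Homo sapiens) for inhibition (on this read-out higher numbers stand for weaker inhibition of growth and lower numbers for stronger inhibition of growth), compound 1 gives 6000 nM, while compound 2 gives 9000 nM, a step of a 1.5-fold higher number from compound 1 to compound 2 (0.18 log units; within the scatter). Compound 3 `Cc1cc(C2(c3ccccc3)C(=O)Nc3ccccc32)c(NS(=O)(=O)c2ccc(C(C)(C)C)cc2)cc1O` carries a different, larger core; how the core of compound 3 differs from the core of compound 1 is not broken down here. In this assay compound 3 gives 800 nM, the strongest growth inhibition of the three, since the numbers of compound 1 and compound 2 both lie beyond the scatter above it. Compound 4 `Cc1cc(C2(c3ccccc3)C(=O)Nc3ccccc32)c(NS(=O)(=O)c2ccc(-c3ccccc3)cc2)cc1O` is not yet measured. It differs from compound 3 by phenyl in place of tert-butyl on an aromatic carbon, the same change, at the same place, that separates compound 1 from compound 2. Because that earlier change gave a 1.5-fold higher number from compound 1 to compound 2 (0.18 log units; within the scatter), the step is expected to be a 1.5-fold higher number from compound 3 to compound 4 (0.18 log units; within the scatter). Compound 4 is therefore estimated at 1200 nM, expected to fall between 500 nM and 3000 nM.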

Compound 4, concentration for 50% growth inhibition: 4000 nM
Compound 4: middle estimate off by 3.3-fold (0.52 log units), on the low side; the measured number lies above the stated range.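

On the larger core, phenyl in place of tert-butyl on an aromatic carbon weakens growth inhibition in this assay, with a 5.0-fold higher number from compound 3 to compound 4 (0.70 log units; beyond the scatter). The size of the step therefore does not carry over from one core to the other: the same change on two cores in this assay, a 1.5-fold higher number (0.18 log units; within the scatter) from compound 1 to compound 2 and a 5.0-fold higher number (0.70 log units; beyond the scatter) from compound 3 to compound 4, 3.3-fold (0.52 log units) apart, beyond the scatter of two such steps. This shows that the core matters for this change, but it does not show why, and two pairs give no rule for any further core.

The compounds shown leave open how an amine or a carboxylic acid on that same aromatic carbon would behave on either core. They also leave open whether the larger step would recur on a third core.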